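Capping One Phenol: From Compound 2 to Compound 3

The source may hold more compounds than are shown below. What is called first, only, known or untested is meant among the compounds shown, and "the series" means these compounds.

Of the compounds shown here, two have so far been measured in a functional assay, read by spectrophotometry, with a stated time of 30 min; on this read-out lower numbers stand for stronger inhibition and higher numbers for weaker inhibition. Compound 1 `CCC(c1ccc(O)c(O)c1)c1ccc(O)c(OC)c1` gives 8280 nM. Compound 2 `CCC(c1ccc(O)c(OC)c1)c1cccc(O)c1O` gives 8430 nM in this assay, which is the higher of the two numbers, yet its gap to compound 1 lies within the scatter, so the two stand level. Among the measured compounds shown here, no step between measured compounds that differ in one place is available, so nothing in these data shows how a single change of this kind moves the read-out. Compound 3 `CCOc1cccc(C(CC)c2ccc(O)c(OC)c2)c1O` differs from compound 2 by ethyl in place of hydrogen on an oxygen on an aromatic ring. Cut one bond further out, the difference reads hydroxy to ethoxy. For compound 3 the expected step of a 2.4-fold higher number from compound 2 to compound 3 (0.38 log units; beyond the scatter) is a moderate rise of the number, toward weaker inhibition, though an outcome within the scatter cannot be excluded. Compound 3 is therefore estimated at 20000 nM in this assay, with a range from 6000 nM to 60000 nM.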

Compound 3, half-maximal inhibitory concentration: 7190 nM
For compound 3 the middle estimate is 2.8-fold (0.44 log units) above the measured one; the measured number falls inside the stated range.
By their numbers in this assay, from the lowest: compounds 3, 1 and 2 (each within the scatter of the next).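

In this assay, ethyl in place of hydrogen on an oxygen on an aromatic ring gives a 1.2-fold lower number from compound 2 to compound 3 (0.07 log units; within the scatter), the first one-place step available in this series. It shows that this oxygen can carry an ethyl group, with its 2 added carbon atoms and the loss of a hydroxy hydrogen, and the number stays level within the scatter. No measurement shown here bears on why the hydroxy to ethoxy change leaves the read-out level.

The compounds shown leave open whether a longer chain such as butoxy, or a chain ending in an amine or a carboxylic acid, would also leave the number level at this oxygen. They also leave open whether ethyl on the remaining hydroxy of compound 3 would behave in the same way.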